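Mirror Image of the Best Amide So Far

The source may report more compounds than this note shows. Statements on the series, on what has been measured and on what is new or still open speak of the compounds shown alone.

Three measured compounds share one core and differ only in the group carried on an amide-type nitrogen. Compound 1 `Cc1ccc(CNC(=O)c2[nH]cnc2C(=O)Nc2ccc(Cl)c(Cl)c2)cc1` carries a 4-methylbenzyl group, and in a functional assay on HL-60 cells (Homo sapiens), with a stated time of 2 days (a lower number here means a stronger inhibitor, a higher number a weaker inhibitor), compound 1 gives 21400 nM. Compound 2 `C[C@H](NC(=O)c1[nH]cnc1C(=O)Nc1ccc(Cl)c(Cl)c1)c1ccccc1` carries a 1-phenylethyl group, and in this assay compound 2 gives 9200 nM, which is a 2.3-fold lower number from compound 1 to compound 2 (0.37 log units; beyond the scatter). Compound 3 `C[C@@H](NC(=O)c1[nH]cnc1C(=O)Nc1ccc(Cl)c(Cl)c1)C(=O)OC(C)(C)C` carries a 1-(tert-butoxycarbonyl)ethyl group, and in this assay compound 3 gives 4600 nM; against the other two this is a 4.7-fold lower number from compound 1 to compound 3 (0.67 log units; beyond the scatter) and a 2.0-fold lower number from compound 2 to compound 3 (0.30 log units; within the scatter). On the numbers shown, compound 3 sits at the low end: clearly separated from compound 1, but not from compound 2, whose number lies within the scatter of its own.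

Compound 4 `C[C@H](NC(=O)c1[nH]cnc1C(=O)Nc1ccc(Cl)c(Cl)c1)C(=O)OC(C)(C)C` is the next step: the two compounds have the same atoms and bonds and differ only in configuration as drawn: 1 of 1 stereo elements differ; a stereocentre at a saturated chain carbon is drawn R in compound 3 and S in compound 4. Among the measured compounds shown here, none of the measured steps bears on such a change; each of them swapped one group for another, whereas here nothing leaves and nothing enters. For the measured compounds named here, no measured step therefore says how large this step should be or in which direction. Mirror-image pairs often, though not always, differ, so the estimated step is a 2.0-fold higher number from compound 3 to compound 4 (0.29 log units; within the scatter), with wide uncertainty. Compound 4 is expected to give about 9000 nM in this assay, within a range from 2000 nM to 40000 nM.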

Compound 4, half-maximal inhibitory concentration: 4900 nM
Estimate against measurement, compound 4: 1.8-fold (0.26 log units) above; low and high end bracket the measured number.
By their numbers in this assay, from the lowest: compounds 3, 4 and 2 (each within the scatter of the next); then compound 1.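

In this assay, inverting the stereocentre at this saturated chain carbon gives a 1.1-fold higher number from compound 3 to compound 4 (0.03 log units; within the scatter), so at this position the assay resolves no difference between the two drawn configurations. Among the compounds shown here, the reading is a clean test of configuration alone, something no earlier step offered, since nothing else changed: the fact that compounds 3 and 4 differ only in the configuration as drawn Tert-butoxycarbonyl in place of phenyl gives a 1.9-fold lower number from compound 2 to compound 4 (0.27 log units; within the scatter), and 1-(tert-butoxycarbonyl)ethyl in place of 4-methylbenzyl gives a 4.4-fold lower number from compound 1 to compound 4 (0.64 log units; beyond the scatter), so with either configuration the separation holds only against the 4-methylbenzyl group.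

From the compounds shown here alone, it remains open whether configuration at this carbon is equally unimportant with other groups on it, and the mirror image of compound 2, which keeps the phenyl, would show this for a second pair. Also open, going by these compounds, is how the number in this assay would respond to a carboxylic acid or a methyl ester in place of the tert-butoxycarbonyl group, or to an ethyl in place of the methyl on the stereocentre.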